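Cyano for butyl on a diacid compound

The source may hold more compounds than are shown below. What is called first, only, known or untested is meant among the compounds shown, and "the series" means these compounds.

- Compound 1 `N#Cc1ccc(C(=O)Nc2ccc(-c3nn[nH]n3)cc2)cc1`: 2.4 mg/kg
- Compound 2 `CCCCc1ccc(C(=O)Nc2cc(C(=O)O)cc(C(=O)O)c2)cc1`: 12.3 mg/kg
- Compound 3 `N#Cc1ccc(C(=O)Nc2ccc(C(=O)O)c(C(=O)O)c2)cc1`: 10.1 mg/kg

All three values come from a functional assay on the whole organism with Rattus norvegicus as the target, at a dose of 25 mg/kg by the intravenous route; a higher number here means that more compound is needed for the effect, a lower number that less compound is needed. Compound 2 has the highest of the three numbers, although compound 3 lies within the scatter of it. The number for compound 1 lies lower than that of compound 2, by more than the scatter.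

The next compound to be measured is compound 4 `N#Cc1ccc(C(=O)Nc2cc(C(=O)O)cc(C(=O)O)c2)cc1`, which differs from compound 2 by one exchange: cyano in place of butyl on an aromatic carbon. In words, the exchanged group sits para to a large group. Going by the values given here, no measured pair isolates this exchange, so the expectation rests on thin ground. Compound 3 also carries cyano and gives 10.1 mg/kg, close to compound 2 at 12.3 mg/kg. Compound 1 carries cyano too, yet gives 2.4 mg/kg, so cyano alone does not settle the number.

The expected change is small, a 1.2-fold lower number from compound 2 to compound 4 (0.09 log units; within the scatter), and no step beyond the scatter is expected. For compound 4 the estimated value is 10 mg/kg, with an expected range of 4 mg/kg to 25 mg/kg.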

Compound 4, dose for 50% inhibition: 1.7 mg/kg
The estimate for compound 4 lay 5.9-fold (0.77 log units) above the measured number; the measured number lies below the stated range.
By their numbers in this assay, from the lowest: compounds 4 and 1 (each within the scatter of the next); then compounds 3 and 2 (each within the scatter of the next).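

In this assay, putting cyano in place of butyl on an aromatic carbon, para to a large group, gives a 7.2-fold lower number from compound 2 to compound 4 (0.86 log units; beyond the scatter). This is the first exchange among these compounds that is isolated in one place, and it shows that on the diacid core the group at this position can move the number beyond the scatter, which the earlier compounds, differing in more than one place, could not show. Nothing measured on these compounds accounts for the step.

The compounds shown leave open whether the step belongs to cyano itself or to the departure of butyl, as only these two groups are compared here. A methyl group, a chlorine atom, an amine or a chain longer than butyl at the same place would help to separate the two readings.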